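The source may report more compounds than this note shows. Statements on the series, on what has been measured and on what is new or still open speak of the compounds shown alone.

Compound 2 `O=c1c(CSC(=S)N2CCCCC2)coc2cc(Cl)ccc12` carries a piperidin-1-yl group on the thiocarbonyl carbon, and in a functional assay on SW480 cells (Homo sapiens) for antiproliferative activity, read by MTT assay, with a stated time of 72 h (a lower number here means a stronger inhibitor, a higher number a weaker inhibitor), compound 2 gives 790 nM, the only plain number among the results shown. Compound 1 `CC(C)N(C(=S)SCc1cc(=O)c2ccc(Cl)cc2o1)C(C)C` sits on a differently built core, and in this assay compound 1 reaches only the limit of > 25000 nM rather than a number; (the limit of > 25000 nM in this assay, at which 1 of the 2 values shown sits). Compound 3 `CC(C)N(C(=S)SCc1coc2cc(Cl)ccc2c1=O)C(C)C` is compound 2 with diisopropylamino in place of piperidin-1-yl on a thiocarbonyl carbon. Going by the values given here, no measured pair shows this change on the shared core, so the step in this assay is expected at a 6.3-fold higher number from compound 2 to compound 3 (0.80 log units; beyond the scatter), toward weaker inhibition. Compound 3 is estimated at 5000 nM, likely between 1500 nM and 25000 nM.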

Compound 3, half-maximal inhibitory concentration: > 25000 nM
Compound 3: a limit, no number (the forecaster's own chance of this, stated with the estimate: 30%); middle value at least 5.0-fold (0.69 log units) from the limit.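

On the shared core, replacing piperidin-1-yl with diisopropylamino on the thiocarbonyl carbon gives an at least 31-fold higher number from compound 2 to compound 3 (1.50 log units; beyond the scatter) in this assay. Going by these compounds alone, this is the first comparison in which only this group changes, and it shows that activity here depends strongly on the group at this place. Compound 3 gives a limit of the assay, not a number: the limit of > 25000 nM in this assay, at which 2 of the 3 values shown sit.

On these data alone, it remains open how a morpholin-4-yl or a diethylamino group at this place would read. Within the data shown here, with only one plain number, it is also unclear which features of piperidin-1-yl matter.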